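Working notes: configuration at the chain stereocentre

The compounds below may be only part of what the source reports. "The series", "measured", "known", "first", "only" and "open" are said of these compounds alone.

Measured in a functional assay on the whole organism (strain Sprague-Dawley) with Rattus norvegicus as the target; on this read-out higher numbers stand for an effect only at larger amounts of compound and lower numbers for an effect already at smaller amounts:
compound 1 `CC(C)C(C(=O)NC(N)=O)C(C)C`: 16 mg/kg
compound 2 `CCC[C@H](C(=O)NC(N)=O)C(C)C`: 37 mg/kg
compound 3 `CCCC(C(=O)NC(N)=O)C(C)C`: 45 mg/kg

In this assay compound 3 gives 45 mg/kg, which lies within the scatter of compound 2. The gap to the third measured compound is clearer: a 2.8-fold higher number from compound 1 to compound 3 (0.45 log units; beyond the scatter). That step exchanges propyl for isopropyl, so it says nothing direct about configuration.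

Compound 4 `CCC[C@@H](C(=O)NC(N)=O)C(C)C` differs from compound 3 as follows: the two compounds have the same atoms and bonds; at least one stereo element is drawn with a configuration in one of them and without one in the other: 1 of 1 stereo elements differ; a stereocentre at a saturated chain carbon is drawn without a configuration in compound 3 and R in compound 4.

The measured step closest to this change is a 1.2-fold higher number from compound 2 to compound 3 (0.09 log units; within the scatter). The only difference behind it is the fact that one of compounds 2 and 3 is drawn with a defined configuration and the other without, at the place where they differ. It involves the same stereocentre, drawn S in compound 2, and it stays within the scatter. Going by the values given here, no compound drawn R has been measured, so the opposite configuration remains open, and a larger difference cannot be ruled out. Since the step to the S form is so small, no clear shift is expected in this assay for the R form. The expected result is a 1.1-fold higher number from compound 3 to compound 4 (0.05 log units; within the scatter), which would not be a step beyond the scatter. For compound 4 the estimated value is 50 mg/kg, with an expected range of 28 mg/kg to 90 mg/kg.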

Compound 4, dose for half-maximal effect: 22 mg/kg
Compound 4: middle estimate off by 2.3-fold (0.36 log units), on the high side, and the stated range ends above it.
By their numbers in this assay, from the lowest: compounds 1, 4, 2 and 3 (each within the scatter of the next, the first and the last beyond it).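

Going by these compounds alone, compound 4 is the first compound here drawn R at this chain stereocentre, and in this assay it gives a step beyond the scatter where drawing the S form had given none (a 2.0-fold lower number from compound 3 to compound 4 (0.31 log units; beyond the scatter)). The two drawn forms themselves stay within the scatter of each other (a 1.7-fold lower number from compound 2 to compound 4 (0.23 log units; within the scatter)), so these compounds do not separate R from S at this position and support no preference for either configuration. The step from the undefined form is modest, and the change behind it lies in a single place: the fact that one of compounds 3 and 4 is drawn with a defined configuration and the other without, at the place where they differ

What proportion of each configuration compound 3 contains is not stated, so its value cannot be read against those of compound 2 and compound 4 as that of a known mixture. As far as these compounds go, whether a longer chain or an amine on the chain in place of propyl would open a gap between the R and S forms at this stereocentre also remains open.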